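The source may report more compounds than this note shows. Statements on the series, on what has been measured and on what is new or still open speak of the compounds shown alone.

Measured so far in a toxicity assay on THP-1 cells (Homo sapiens) for inhibition (on this read-out higher numbers stand for lower toxicity in this test and lower numbers for higher toxicity in this test), all three values being limits:
- compound 1 `Cc1cccc(-c2cnc(NC(=O)c3ccc(F)cc3)n2C)c1`: > 100000 nM
- compound 2 `COc1ccccc1-c1cnc(NC(=O)c2ncc[nH]2)n1C`: > 50000 nM
- compound 3 `Cn1c(-c2ccccc2Br)cnc1NC(=O)c1ccc(F)cc1`: > 100000 nM

Compound 3 sits at the limit of > 100000 nM in this assay, at which 2 of the 3 values shown sit. Compound 2 sits at the limit of > 50000 nM in this assay, at which 1 of the 3 values shown sits. Within the data shown here, no compound has yet given a number, so no ranking can be drawn.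

Compound 4 `COc1ccccc1-c1cnc(NC(=O)c2ccc(F)cc2)n1C` follows from compound 3 by methoxy in place of bromo on an aromatic carbon, (methoxy in place of bromo on an aromatic carbon). Among the measured compounds shown here, the only measured step with a bearing on this change is a step that the two limits leave unreadable from compound 1 to compound 3. It shows that a change of group on this same aryl ring left the read-out at the limit, but it gives no size to carry over. Compound 2 already carries the 2-methoxyphenyl group, with a different group on the amide carbonyl, and its > 50000 nM is a limit.

No step beyond the scatter is therefore expected in this assay, and no direction can be assigned. The expected step is a number no higher from compound 3 to compound 4 (the limit leaves the size open), which rests on compound 3 and its limit of > 100000 nM. A further limit is the most likely report for the next measurement. The estimate for compound 4 is 100000 nM. The expected range runs from 40000 nM to 200000 nM.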

Compound 4, half-maximal cytotoxic concentration: > 100000 nM
Compound 4: a limit, no number; the forecaster's own chance of this, stated with the estimate: 85%; the middle value lies on the limit itself.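

In this assay, among these compounds, compound 4 reads as a limit, as do compounds 1, 2 and 3, so no step between compound 4 and any of these three can be read. The compounds shown leave open whether 2-methoxyphenyl, 2-bromophenyl, 3-methylphenyl, 4-fluorophenyl or 1H-imidazol-2-yl changes the read-out at all, since none has yet given a number.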